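A few compounds are considered here, and "the series" means these few. Any claim that something is new, unique, unknown or untested is made for them only; others in the source may bear on it.

Measured compounds:
compound 1, `CCn1nnc(-c2sc(-c3cccc(O)c3)nc2O)n1`, gives 239 nM in an assay on HEK293 cells for inhibition of transient receptor potential cation channel subfamily M member 8 (Homo sapiens), read by FLIPR, with stated times of 5 min and 3 min; a lower number here means a stronger inhibitor, a higher number a weaker inhibitor;
compound 2, `O=C(c1sc(-c2cccc(F)c2)nc1O)N1CCCCCO1`, gives 32 nM in this assay.

Of the two numbers in hand, compound 2 has the lower one, and the gap to compound 1 lies beyond the scatter; the two structures differ in more than one place, so only the two values themselves can be compared.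

Compound 3, `O=C(c1sc(-c2cccc(F)c2)nc1O)N1CCOCC1`, has not yet been measured in this assay. It differs from compound 2 in one place:

a group of 6 heavy atoms (4 carbon, 1 nitrogen, 1 oxygen; one six-membered non-aromatic ring with 2 hetero atoms) in place of a group of 7 heavy atoms (5 carbon, 1 nitrogen, 1 oxygen; one seven-membered non-aromatic ring with 2 hetero atoms), on a carbonyl carbon

For the measured compounds named here, no step between measured compounds speaks to a change of this kind, so the expectation rests on compound 2 alone. A change of one atom in the ring on the carbonyl carbon is expected to move the number little, most likely within the scatter or slightly upward; the step of a 1.7-fold higher number from compound 2 to compound 3 (0.24 log units; within the scatter) is the estimated size. On that basis compound 3 is expected to give about 55 nM in this assay, with a likely range from 15 nM to 200 nM.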

Compound 3, half-maximal inhibitory concentration: 12200 nM
For compound 3 the middle estimate is 220-fold (2.35 log units) below the measured one, outside the stated range (above it).
By their numbers in this assay, from the lowest: compound 2; then compound 1; then compound 3.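

The ring on the carbonyl carbon proved far from tolerant of a seemingly small exchange: putting morpholin-4-yl in place of the seven-membered ring gives a 380-fold higher number from compound 2 to compound 3 (2.58 log units; beyond the scatter) in this assay on an otherwise unchanged structure. This large loss arises even though the two groups have the same counts of hydrogen-bond donors and acceptors and neither carries a net charge, so those counts do not separate them. No measurement shown here explains the loss.

On these data alone, the two compounds differ in ring size and in the ring's hetero-atom arrangement at once, so the share of each in the step remains open. Piperidin-1-yl, azepan-1-yl or 1,2-oxazinan-2-yl on the same carbonyl carbon would begin to separate these two differences.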